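A Thiazole Acetic Acid Series: From Sulfamoylphenyl to Azetidinylpyridyl

The compounds below may be only part of what the source reports. "The series", "measured", "known", "first", "only" and "open" are said of these compounds alone.

Measured compounds:
- compound 1 `NS(=O)(=O)c1cccc(-c2nc(C(c3ccc(F)cc3)c3ccc(F)cc3)sc2CC(=O)O)c1`: 55%
- compound 2 `O=C(O)Cc1sc(C(c2ccccc2)c2ccc(O)cc2)nc1-c1ccc(F)cc1`: 80%

Of the compounds shown here, two have been tested in an in vitro functional assay on HEK285-7 cells for antagonist activity at prostaglandin D2 receptor 2 (Homo sapiens), read by BRET and beta-arrestin recruitment; on this read-out higher numbers stand for larger maximal responses and lower numbers for smaller maximal responses. Compound 1 gives 55%, and compound 2 gives 80%. Of these two numbers, compound 1 stands lowest; the number for compound 2 lies higher by a distance beyond the usual scatter of repeated measurements. Compound 2 differs from compound 1 in more than one place, so no single change can be linked to that gap.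

Compound 3 `O=C(O)Cc1sc(C(c2ccc(F)cc2)c2ccc(F)cc2)nc1-c1ccnc(N2CCC2)c1` has not yet been measured. It differs from compound 1 in one place: 2-(azetidin-1-yl)pyridin-4-yl in place of 3-sulfamoylphenyl on an aromatic carbon. The leaving group and the entering group are set out in that comparison, and the shared core is untouched.

Among the measured compounds shown here, with no single-change step available among the measured compounds, the direction of this change is uncertain. The step from compound 1 to compound 3 in this assay is estimated to be small, a number 7 percentage points higher from compound 1 to compound 3 (within the scatter), not clearly beyond the scatter. The expected result for compound 3 is 62%, within a range from 40% to 85%.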

Compound 3, largest response reached (reported as efficacy), in percent of the reference or control that the assay uses: 80%
Beside the measured number, compound 3's estimate is 18 percentage points below it, and the stated range covers the measured number.
By their numbers in this assay, from the lowest: compound 1; then compounds 2 and 3 (each within the scatter of the next).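

In this assay, putting 2-(azetidin-1-yl)pyridin-4-yl in place of 3-sulfamoylphenyl on the aromatic carbon next to the ring nitrogen gives a number 25 percentage points higher from compound 1 to compound 3 (beyond the scatter), while the rest of the structure stays the same. Among the compounds shown here, this is the first comparison that differs in one place only, so it shows that the group at this position can by itself move the maximal response by more than the usual scatter. The two groups have the same count of heavy atoms and of hydrogen-bond acceptors, but they differ in other ways: the leaving group has a hydrogen-bond donor and a sulfur atom, and the entering group has a four-membered ring and a ring nitrogen, and nothing available explains why the number changes.

This single exchange alters several features at once, so it cannot show whether the pyridine ring or the azetidine ring accounts for the step. A simple pyridin-4-yl group, or a dimethylamino group in place of the azetidine ring, would help separate the two, and a single pair cannot show whether the step would hold on another core.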